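Second fluoro on the core of compound 1

This account rests on a few compounds, and the source may have more. Where it says the series, first, only, none or still open, it means among the compounds named here.

Compound 1 `NC(=O)/C=C1\CCc2c(F)cccc21` gives 34% in a functional assay on the whole organism with Rattus norvegicus as the target, at a dose of 20 mg/kg by the oral route (on this read-out lower numbers stand for less inhibition and higher numbers for more inhibition at the one dose given (going by the name of the read-out)), the higher of the two numbers in hand. Compound 2 `Cc1cccc2c1CC/C2=C\C(N)=O` gives 13% in this assay; the step of a number 21 percentage points lower from compound 1 to compound 2 (beyond the scatter) belongs to methyl in place of fluoro on an aromatic carbon, modest but beyond the scatter. Compound 3 `NC(=O)/C=C1\CCc2c(F)ccc(F)c21` differs from compound 1 by fluoro in place of hydrogen on an aromatic carbon. Going by the values given here, no measured step adds a fluoro to a core that already carries one; the single known step swaps fluoro for methyl and does not bear on this change. A step of a number 2 percentage points higher from compound 1 to compound 3 (within the scatter) is therefore expected, within the scatter and without a clear direction. Compound 3 is estimated at 36% in this assay, between 16% and 56%.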

Compound 3, a percentage reported as inhibition, in the whole organism at one dose (the size of the read-out at that dose, not a potency): 67%
Beside the measured number, compound 3's estimate is 31 percentage points below it, outside the stated range (above it).
By their numbers in this assay, from the lowest: compound 2; then compound 1; then compound 3.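

Fluoro in place of hydrogen on this aromatic carbon, para to a fluoro group, gives a number 33 percentage points higher from compound 1 to compound 3 (beyond the scatter) in this assay. The earlier step concerned only the carbon bearing the first fluoro; this one shows that the read-out also responds strongly to a change at this second position. No measurement at hand explains the gain.
Going by these compounds, whether the gain is particular to fluoro remains open, and chloro, methoxy or an amine at this position would test that. Also open, on these data alone, is whether it persists when the first fluoro is replaced by hydrogen.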